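A few compounds are considered here, and "the series" means these few. Any claim that something is new, unique, unknown or untested is made for them only; others in the source may bear on it.

Compound 1 `O=C(O)CCc1ccc(NC(=O)c2nnc(COc3cccc(Cl)c3)s2)cc1`, compound 2 `O=C(O)CCc1ccc(NC(=O)c2nnc(COc3cccc(C(F)(F)F)c3)s2)cc1` and compound 3 `CCc1ccc(OCc2nnc(C(=O)Nc3ccc(CCC(=O)O)cc3)s2)cc1` share one core and differ only in the aryl group on an oxygen on a saturated carbon. In a functional assay on CHO cells for agonist activity at Free fatty acid receptor 1 (Homo sapiens), read by FLIPR and calcium flux, tested at 1 uM (on this read-out higher numbers stand for an effect only at larger amounts of compound and lower numbers for an effect already at smaller amounts), compound 1 gives 1570 nM, compound 2 gives 3090 nM and compound 3 gives 1170 nM. Compound 3 is set apart beyond the scatter only from compound 2, through a 2.6-fold lower number from compound 2 to compound 3 (0.42 log units; beyond the scatter); the steps of a 2.0-fold higher number from compound 1 to compound 2 (0.29 log units; within the scatter) and a 1.3-fold lower number from compound 1 to compound 3 (0.13 log units; within the scatter) both lie within the scatter, so compound 3 and compound 1 cannot be told apart on these numbers.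

Compound 4 `Cc1ccc(OCc2nnc(C(=O)Nc3ccc(CCC(=O)O)cc3)s2)cc1` is the next compound to be tested. Its change from compound 3 is hydrogen in place of methyl on a saturated chain carbon bound to an aromatic carbon, which, seen one bond further out, turns 4-ethylphenoxy into 4-methylphenoxy. Going by the values given here, none of the measured steps makes exactly this change, but all three swapped the aryl group in this same position, and even the largest of them, a 2.6-fold lower number from compound 2 to compound 3 (0.42 log units; beyond the scatter), was only modest. The expected step of a 1.3-fold higher number from compound 3 to compound 4 (0.11 log units; within the scatter) for compound 4 is therefore small, within the scatter, leaning if anywhere toward a higher number. Compound 4 is estimated at 1500 nM, with a range from 600 nM to 3800 nM.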

Compound 4, half-maximal effective concentration: 2170 nM
Compound 4: middle estimate off by 1.4-fold (0.16 log units), on the low side, within the range that was stated.
By their numbers in this assay, from the lowest: compounds 3, 1, 4 and 2 (each within the scatter of the next, the first and the last beyond it).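

Going by these compounds alone, compound 4 is the first direct test of the length of the chain on this aryl group, and cutting 4-ethylphenyl back to 4-methylphenyl gives a 1.9-fold higher number from compound 3 to compound 4 (0.27 log units; within the scatter), so the methyl that leaves can be lost with no change that these numbers can resolve. Within the data shown here, the 4-methylphenyl group also cannot be told apart from either aryl group with a substituent of another kind, with a 1.4-fold lower number from compound 2 to compound 4 (0.15 log units; within the scatter) and a 1.4-fold higher number from compound 1 to compound 4 (0.14 log units; within the scatter), which leaves compound 2 and compound 3 as the only pair separated beyond the scatter. Nothing measured here bears on why the values fall as they do.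

The compounds shown leave open whether a longer chain, as in 4-propylphenyl, or an amine or a hydroxyl on the saturated chain carbon bound to an aromatic carbon, would move the number well beyond the scatter. They also leave open what plain phenyl, with no group on the ring at all, or 4-methoxyphenyl would give in this position, and so whether any aryl group here can produce a large step.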